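Chloro Substitution on the Pyrazole Series Pending Measurement

The source may hold more compounds than are shown below. What is called first, only, known or untested is meant among the compounds shown, and "the series" means these compounds.

Compound 1 `COc1ccc(OC)c(-c2cc(-c3ccccc3)nn2-c2ccc(S(=O)(=O)NC(C)=O)cc2)c1` and compound 2 `COc1ccc(OC)c(-c2cc(-c3ccc(Cl)cc3)nn2-c2ccc(S(=O)(=O)NC(C)=O)cc2)c1` share one core; compound 3 `Oc1ccc(O)c(-c2cc(-c3ccccc3)nn2-c2ccccc2)c1` and compound 4 `Oc1ccc(O)c(-c2cc(-c3ccc(Cl)cc3)nn2-c2ccccc2)c1` share another. The difference between the two cores is not broken down here. In a functional assay on cells (Leukemia cell, Homo sapiens) for cytotoxicity, read by sulforhodamine B assay, with a stated time of 48 h (on this read-out higher numbers stand for weaker inhibition of growth and lower numbers for stronger inhibition of growth), compound 1 gives 7400 nM and compound 2 gives 7450 nM, so the step of a 1.0-fold higher number from compound 1 to compound 2 (0.00 log units; within the scatter), the change (chloro in place of hydrogen on an aromatic carbon), leaves the number essentially unchanged. Compound 3 gives 35700 nM, the highest of the three numbers. Compound 4 carries the same change, (chloro in place of hydrogen on an aromatic carbon), placed on an aromatic carbon of a six-membered aromatic ring of carbon only, para to a large group, exactly as in compound 2. The step from compound 3 to compound 4 is therefore expected to be small, a 1.1-fold lower number from compound 3 to compound 4 (0.03 log units; within the scatter), because the earlier step of a 1.0-fold higher number from compound 1 to compound 2 (0.00 log units; within the scatter) lay within the scatter. Compound 4 is estimated at 33000 nM, between 12000 nM and 90000 nM.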

Compound 4, concentration for 50% growth inhibition: 3430 nM
Estimate against measurement, compound 4: 9.6-fold (0.98 log units) above, outside the stated range (below it).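

In this assay, chloro in place of hydrogen on an aromatic carbon gives a 10-fold lower number from compound 3 to compound 4 (1.02 log units; beyond the scatter), so the size of the phenyl to 4-chlorophenyl step does not carry from one core to the other: the same change on two cores in this assay, a 1.0-fold higher number (0.00 log units; within the scatter) from compound 1 to compound 2 and a 10-fold lower number (1.02 log units; beyond the scatter) from compound 3 to compound 4, 10-fold (1.02 log units) apart, beyond the scatter of two such steps. The step on the core of compound 1 therefore gives no reliable guide to the step on the core of compound 3. Within the data shown here, this rests on only two matched pairs, and it does not show which difference between the cores goes with the gap, nor how the change behaves on any other core.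

Still open, as far as these compounds go, is which part of the cores separates the two steps. Also open, from the compounds shown here alone, is whether bromo or methyl at the same place would follow chloro on either core.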